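Swapping the Ring on the Thiocarbonyl Carbon

This account rests on a few compounds, and the source may have more. Where it says the series, first, only, none or still open, it means among the compounds named here.

Measured so far in a functional assay on HeLa cells (Homo sapiens) for cytotoxicity, read by MTT assay, with a stated time of 72 h, tested at 10 uM; on this read-out lower numbers stand for less inhibition of growth and higher numbers for more inhibition of growth at the one concentration tested:
Compound 1, `Cc1ccnc(/C(N)=N/NC(=S)N2CCCC2)c1`, gives 67%.
Compound 2, `N/C(=N\NC(=S)N1CCOCC1)c1ccc(F)cn1`, gives 81.9%.
Compound 3, `N/C(=N\NC(=S)N1CCOCC1)c1ccccn1`, gives 56.3%.

Compound 3 stands lowest of the three, with compound 1 nearest and compound 2 furthest. Among the compounds with values here, the only single-point step known, a number 25.6 percentage points lower from compound 2 to compound 3 (beyond the scatter), concerns a ring substituent and does not touch the change now at hand. Compound 4, `N/C(=N\NC(=S)N1CCCC1)c1ccccn1`, differs from compound 3 by pyrrolidin-1-yl in place of morpholin-4-yl on a thiocarbonyl carbon. Compound 1 also carries pyrrolidin-1-yl and sits higher than compound 3, but it differs in two places, so its value is only a loose hint. The step of a number 5.7 percentage points higher from compound 3 to compound 4 (within the scatter) is therefore expected to be small, within or just beyond the scatter, upward if anything. Compound 4 is estimated at 62%, between 46% and 78%.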

Compound 4, percent growth inhibition at one concentration: 63.5%
Compound 4: middle estimate off by 1.5 percentage points, on the low side, within the range that was stated.
By their numbers in this assay, from the lowest: compounds 3, 4 and 1 (each within the scatter of the next, the first and the last beyond it); then compound 2.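

In this assay, pyrrolidin-1-yl in place of morpholin-4-yl on the thiocarbonyl carbon gives a number 7.2 percentage points higher from compound 3 to compound 4 (within the scatter), so this position accepts either ring with no real difference on this core. Hydrogen in place of methyl on an aromatic carbon gives a number 3.5 percentage points lower from compound 1 to compound 4 (within the scatter), which shows that this methyl makes no clear difference either. No supporting measurement is available to explain these results.

Still open, on these data alone, is whether piperidin-1-yl or an open-chain dimethylamino group on the thiocarbonyl carbon would fit as well. Also open, as far as these compounds go, is whether pyrrolidin-1-yl would match morpholin-4-yl on a fluoro-bearing ring.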